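Deacetylation of the side-chain acetoxy: compound 3 to compound 4

This account rests on a few compounds, and the source may have more. Where it says the series, first, only, none or still open, it means among the compounds named here.

Compound 3 `CCCC[C@@H](C)C[C@@H](C)C(=O)N(C)[C@@H](CC(C)C)C(=O)N[C@H](C(=O)N(C)[C@H](C(=O)N1CCC[C@H]1C(=O)N1C(=O)CC[C@@H]1C)C(C)C)[C@@H](C)OC(C)=O` gives 5000 nM in a functional assay on NCI-H460 cells (Homo sapiens) for cytotoxicity, read by MTT assay, with a stated time of 48 h (a higher number here means a weaker inhibitor, a lower number a stronger inhibitor), the highest of the three numbers in hand. Compound 2 `CCCC[C@@H](C)C[C@@H](C)C(=O)N(C)[C@@H](CC(C)C)C(=O)N[C@H](C(=O)N(C)[C@H](C(=O)N1C[C@@H](O)C[C@H]1C(=O)N1C(=O)CC[C@@H]1C)C(C)C)[C@@H](C)OC(C)=O` gives 2800 nM, and the step of a 1.8-fold higher number from compound 2 to compound 3 (0.25 log units; within the scatter) lies within the scatter. Compound 1 `CCCC[C@@H](C)C[C@@H](C)C(=O)N(C)[C@@H](CC(C)C)C(=O)N[C@H](C(=O)N(C)[C@H](C(=O)N1CCC[C@H]1C(=O)N1C(=O)C=C[C@@H]1C)C(C)C)[C@@H](C)O` gives 650 nM, the lowest of the three.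

Compound 4 `CCCC[C@@H](C)C[C@@H](C)C(=O)N(C)[C@@H](CC(C)C)C(=O)N[C@H](C(=O)N(C)[C@H](C(=O)N1CCC[C@H]1C(=O)N1C(=O)CC[C@@H]1C)C(C)C)[C@@H](C)O` differs from compound 3 in one place: hydrogen in place of acetyl on an oxygen on a saturated carbon. Within the data shown here, no measured step isolates this change. Among the measured compounds shown here, the only single-site step recorded, from compound 2 to compound 3, concerns a hydroxy on a saturated ring carbon and does not bear on the side-chain oxygen. For the measured compounds named here, what the numbers do show is that compound 1, the only compound carrying the free hydroxy, sits well below both acetoxy compounds, though compound 1 also differs from compound 3 in its ring unsaturation, so the two changes cannot be separated.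

On that basis a lower number is expected for compound 4, with the step of a 3.8-fold lower number from compound 3 to compound 4 (0.59 log units; beyond the scatter) estimated as moderate. Compound 4 is expected to give about 1300 nM in this assay, between 400 nM and 4000 nM.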

Compound 4, half-maximal inhibitory concentration: > 30000 nM
Compound 4 ended at the assay's limit; the forecaster's own chance of this, stated with the estimate: 5%; middle value at least 23-fold (1.36 log units) away from the limit.
By their numbers in this assay, from the lowest: compound 1; then compounds 2 and 3 (each within the scatter of the next). At a limit, above all of these: compound 4.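

In this assay, compound 4 stands at a limit of the assay, > 30000 nM. On the core with the saturated ring, acetoxy to hydroxy gives an at least 6.0-fold higher number from compound 3 to compound 4 (0.77 log units; beyond the scatter), so the free hydroxy by itself does not carry the low number of compound 1. With the hydroxy kept and only the group on the carbonyl carbon changed, the step is an at least 46-fold higher number from compound 1 to compound 4 (1.66 log units; beyond the scatter), which shows that the ring double bond present in compound 1 and absent from compound 4 matters strongly in this series.

Still open, going by these compounds, is whether acetoxy in place of hydroxy changes the number when that ring double bond is present. Also open, on these data alone, is what a methoxy or an amine would give on this saturated carbon.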